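Compound 3 in the Light of Compound 2

This account rests on a few compounds, and the source may have more. Where it says the series, first, only, none or still open, it means among the compounds named here.

Compound 2 `CCc1c(C)[nH]c2cc(OCCOc3ccccc3)c(Cl)cc2c1=O` sits in an ADME assay on J774 cells (Mus musculus) for antiproliferative activity, with a stated time of 72 h (on this read-out lower numbers stand for an effect already at smaller amounts and higher numbers for an effect only at larger amounts of compound), at a limit rather than a number: compound 2 gives > 28000 nM. For the measured compounds named here, compound 1 `CCCCc1cc2c(=O)c(CC)c(C)[nH]c2cc1OCCOc1ccccc1` in this assay gives 1000 nM, and the one measured step is an at least 28-fold higher number from compound 1 to compound 2 (1.44 log units; beyond the scatter). Compound 3 `CCc1c(C)[nH]c2cc(OCOC)c(Cl)cc2c1=O` differs from compound 2 in another place: methoxy in place of phenoxymethyl on a saturated chain carbon bound to an oxygen on an aromatic ring. Going by the values given here, no measured step touches this change, so no direction can be read from the data for it. Compound 3 is therefore expected to remain close to the limit, with an estimate of 30000 nM and a range from 10000 nM to 100000 nM, which corresponds to an expected step that the limit leaves unreadable from compound 2 to compound 3.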

Compound 3, half-maximal effective concentration: 19000 nM
Compound 3: middle estimate off by 1.6-fold (0.20 log units), on the high side; measured number inside the range.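

In this assay, methoxy in place of phenoxymethyl gives an at least 1.4-fold lower number from compound 2 to compound 3 (0.16 log units; that floor lies within the scatter), so the chloro series now has a measured number rather than only a limit. The loss of the six-membered aromatic ring therefore does not push the value beyond the range of the assay. The true size of the step cannot be read because compound 2 stands at a limit: the limit of > 28000 nM in this assay, at which 1 of the 3 values shown sits.

As far as these compounds go, what an amine or a longer chain in place of methoxy would give stays open. So does whether methoxy would read the same with butyl in place of chloro.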